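The source may report more compounds than this note shows. Statements on the series, on what has been measured and on what is new or still open speak of the compounds shown alone.

Going by the values given here, in an ADME assay on MT4 cells (Homo sapiens) for cytotoxicity, read by MTT assay, with a stated time of 4 days (a lower number here means that less compound is tolerated, a higher number that more compound is tolerated), three compounds sharing one core have numbers so far. Compound 1 `O=C(COc1cccc2ccccc12)N/N=C/c1ccc(O)cc1` gives 26.5 ug/mL and compound 2 `O=C(COc1cccc2ccccc12)N/N=C/c1cccc(O)c1` gives 32.6 ug/mL, which lie within the scatter of each other, with a 1.2-fold higher number from compound 1 to compound 2 (0.09 log units; within the scatter). Compound 3 `CSc1ccc(/C=N/NC(=O)COc2cccc3ccccc23)cc1` gives 68.3 ug/mL, the highest of the three and clear of both others, with a 2.6-fold higher number from compound 1 to compound 3 (0.41 log units; beyond the scatter) and with a 2.1-fold higher number from compound 2 to compound 3 (0.32 log units; beyond the scatter). Both of these steps are modest.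

Compound 4 `Cc1ccc(/C=N/NC(=O)COc2cccc3ccccc23)cc1` differs from compound 3 in one place, with methyl in place of methylsulfanyl on an aromatic carbon, para to a large group: methyl in place of methylsulfanyl on an aromatic carbon. Among the compounds with values here, no measured step makes this exchange. The closest evidence is the pair of steps into compound 3, each of which puts methylsulfanyl where a hydroxy-bearing ring stood before. With a 2.6-fold higher number from compound 1 to compound 3 (0.41 log units; beyond the scatter) and a 2.1-fold higher number from compound 2 to compound 3 (0.32 log units; beyond the scatter) as the largest changes seen around this ring, only a small move is expected here. The expected change is a 1.2-fold lower number from compound 3 to compound 4 (0.09 log units; within the scatter), a slight drop that would not clear the scatter. Compound 4 is estimated at 55 ug/mL, within an expected range of 26 ug/mL to 115 ug/mL.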

Compound 4, half-maximal cytotoxic concentration: 83.9 ug/mL
The estimate for compound 4 lay 1.5-fold (0.18 log units) below the measured number; the measured number falls inside the stated range.
By their numbers in this assay, from the lowest: compounds 1 and 2 (each within the scatter of the next); then compounds 3 and 4 (each within the scatter of the next).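

In this assay, exchanging methylsulfanyl for methyl on this aromatic carbon, para to a large group, makes no difference that can be told from the scatter, with a 1.2-fold higher number from compound 3 to compound 4 (0.09 log units; within the scatter). Among these compounds, then, the sulfur atom is not required for a number at this level: compound 3 and compound 4 sit together, and the separation from the hydroxy-bearing compounds holds with methyl as it did with methylsulfanyl, with a 3.2-fold higher number from compound 1 to compound 4 (0.50 log units; beyond the scatter) and with a 2.6-fold higher number from compound 2 to compound 4 (0.41 log units; beyond the scatter), both modest steps. No measurement at hand says what lies behind this separation between the hydroxy compounds and the other two.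

The compounds shown leave open how an amine, a carboxylic acid or a longer chain such as propyl would read on this same aromatic carbon, since only hydroxy, methylsulfanyl and methyl stand there so far. They also leave open whether methyl would give a similar number on the ring carbon that carries the hydroxy group in compound 2, as 3-methylphenyl in place of 4-methylphenyl.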